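Testing compound 4 against a limit

This account rests on a few compounds, and the source may have more. Where it says the series, first, only, none or still open, it means among the compounds named here.

Measured in a functional assay on HEY cells (Homo sapiens) for cytotoxicity, read by MTT assay, with a stated time of 72 h; a lower number here means a stronger inhibitor, a higher number a weaker inhibitor:
Compound 1 `N[C@H]1CC[C@H](Nc2c(C(=O)NCc3ccco3)nc(Br)c3cccnc23)CC1`: > 10000 nM (a limit)
Compound 2 `N[C@H]1CC[C@H](Nc2c(C(=O)NCc3ccc(F)cc3)nc(Br)c3cccnc23)CC1`: "not determined" (no result reported)
Compound 3 `C[C@H](NC(=O)c1nc(Br)c2cccnc2c1N[C@H]1CC[C@H](N)CC1)c1ccc(F)cc1`: > 10000 nM (a limit)

In this assay compound 3 gives > 10000 nM, which is a limit and not a number. Compound 3 therefore has no exact place among the values, and compound 2 adds no result to compare.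

Compound 4 `N[C@H]1CC[C@H](Nc2c(C(=O)NCc3cccc(C(F)(F)F)c3)nc(Br)c3cccnc23)CC1` carries 3-(trifluoromethyl)benzyl in place of 1-(4-fluorophenyl)ethyl on an amide-type nitrogen.

Going by the values given here, the only measured step changes the group on the same nitrogen, and it has no readable size: a step that the two limits leave unreadable from compound 1 to compound 3. The wider evidence is the limit of > 10000 nM in this assay, at which 2 of the 3 values shown sit. These results give no sign of a change in either direction, so no step beyond the scatter is expected in this assay.

The expected step is a number no higher from compound 3 to compound 4 (the limit leaves the size open). Compound 4 is estimated at 10000 nM, with an expected range of 3000 nM to 30000 nM.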

Compound 4, half-maximal inhibitory concentration: 12000 nM
For compound 4 the middle estimate is 1.2-fold (0.08 log units) below the measured one; the range from low to high includes it.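

Going by these compounds alone, compound 1 and compound 3 are recorded only as limits in this assay, so no step from either of them to compound 4 can be read. The compounds shown leave open whether changing the group on the amide-type nitrogen shifts the value in this assay at all, and the evidence remains: the limit of > 10000 nM in this assay, at which 2 of the 4 values shown sit.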